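Methyl Sulfide in Place of the Aryl Sulfide

The source may report more compounds than this note shows. Statements on the series, on what has been measured and on what is new or still open speak of the compounds shown alone.

Compound 2 `COc1cccc(Sc2c(NS(=O)(=O)c3ccc(C(C)(C)C)cc3)noc2C)c1` gives 300 nM in an assay on COS-7 cells for displacement of a labelled ligand from Endothelin receptor type B (Sus scrofa) (a higher number here means a weaker inhibitor, a lower number a stronger inhibitor), the lower of the two numbers shown, though the step of a 1.7-fold lower number from compound 1 to compound 2 (0.24 log units; within the scatter) lies within the scatter; compound 1 `COc1cccc(Sc2c(NS(=O)(=O)c3ccc(C(C)(C)C)cc3)noc2CCCC#N)c1` gives 520 nM in this assay. Compound 3 `CSc1c(NS(=O)(=O)c2ccc(C(C)(C)C)cc2)noc1C` differs from compound 2 by methyl in place of 3-methoxyphenyl on a sulfur. For the measured compounds named here, no measured step touches the group on this sulfur; the one step known alters the chain on the other side of the shared core. Since the change removes the one six-membered aromatic ring counted there, compound 3 is expected to read weaker, a step of a 10-fold higher number from compound 2 to compound 3 (1.00 log units; beyond the scatter). Compound 3 is estimated at 3000 nM, between 700 nM and 15000 nM.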

Compound 3, half-maximal inhibitory concentration: 35000 nM
Estimate against measurement, compound 3: 12-fold (1.07 log units) below; measured number above the stated range.
By their numbers in this assay, from the lowest: compounds 2 and 1 (each within the scatter of the next); then compound 3.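

On the group carried by this sulfur, the measured step is large: methyl in place of 3-methoxyphenyl gives a 120-fold higher number from compound 2 to compound 3 (2.07 log units; beyond the scatter) in this assay. The earlier change on the other side of the shared core, a 1.7-fold lower number from compound 1 to compound 2 (0.24 log units; within the scatter), showed no such sensitivity. Nothing at hand explains the size of the step on the sulfur. The compounds shown leave open whether a plain phenyl, without the methoxy group, would keep the reading of compound 2. They also leave open how an ethyl or a benzyl on this sulfur would read.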